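This account rests on a few compounds, and the source may have more. Where it says the series, first, only, none or still open, it means among the compounds named here.

Compound 1 `N#Cc1cnc(NCc2cnccc2C(F)(F)F)cc1NC[C@H]1C[C@@H](O)C1` gives 300 nM in an assay on isolated protein for inhibition of protein kinase C theta type (Homo sapiens), read by TR-FRET, with a stated time of 2 h (a higher number here means a weaker inhibitor, a lower number a stronger inhibitor), the lower of the two numbers in hand. Compound 2 `N#Cc1cnc(NCc2ccccc2C(F)(F)F)cc1N[C@H]1CC[C@H](O)CC1` gives 4000 nM in this assay, a gap from compound 1 that is beyond the scatter. Compound 3 `CO[C@H]1CC[C@@H](Nc2cc(NCc3cnccc3C(F)(F)F)ncc2C#N)CC1` has not yet been measured in this assay. It differs from compound 1 in one place: 4-methoxycyclohexyl in place of (3-hydroxycyclobutyl)methyl on a nitrogen on an aromatic ring. For the measured compounds named here, no measured pair carries this change on its own, and compound 2 differs from compound 1 in more than this one place. The step of a 5.0-fold higher number from compound 1 to compound 3 (0.70 log units; beyond the scatter) is expected to run toward a higher number, beyond the scatter. Compound 3 is expected at 1500 nM, within 400 nM to 6000 nM.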

Compound 3, half-maximal inhibitory concentration: 58 nM
Estimate against measurement, compound 3: 26-fold (1.41 log units) above; measured number below the stated range.
By their numbers in this assay, from the lowest: compound 3; then compound 1; then compound 2.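

On the nitrogen on an aromatic ring, 4-methoxycyclohexyl in place of (3-hydroxycyclobutyl)methyl gives a 5.2-fold lower number from compound 1 to compound 3 (0.71 log units; beyond the scatter) in this assay, so this position accepts the six-membered ring with its methoxy group and no hydrogen-bond donor in the group. The change alters ring size, attachment and oxygen substituent together. Nothing available bears on the reason for this step.

No compound shown separates the contribution of the six-membered ring from that of the methoxy group. Going by these compounds, how an amine such as 4-aminocyclohexyl or a longer ether such as 4-ethoxycyclohexyl would read at this position remains open.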